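Truncating the chain at compound 3 to a methyl

A few compounds are considered here, and "the series" means these few. Any claim that something is new, unique, unknown or untested is made for them only; others in the source may bear on it.

Compound 3 `CCCCNc1nc(N)nc(C)c1CCCn1cncn1` gives 1050 nM in an assay on HEK293 cells for agonist activity at Toll-like receptor 8 (Homo sapiens), read by spectrophotometry (on this read-out higher numbers stand for an effect only at larger amounts of compound and lower numbers for an effect already at smaller amounts), second highest of the three numbers. Its neighbours are compound 1 `CCCCNc1nc(N)nc(C)c1CCc1ccccc1` with 1190 nM and compound 2 `CCCCNc1nc(N)nc(C)c1CCCN(C)C` with 126 nM. The step to compound 4 `CCCCNc1nc(N)nc(C)c1C` is hydrogen in place of 2-(1H-1,2,4-triazol-1-yl)ethyl on a saturated chain carbon bound to an aromatic carbon. For the measured compounds named here, none of the measured steps removes the chain; they only swap its end group: a 1.1-fold lower number from compound 1 to compound 3 (0.05 log units; within the scatter), a 9.4-fold lower number from compound 1 to compound 2 (0.98 log units; beyond the scatter), an 8.3-fold higher number from compound 2 to compound 3 (0.92 log units; beyond the scatter). Those steps show the chain end can shift the number modestly but give no guide to losing the chain entirely. Loss of the chain is expected to raise the number, so for compound 4 the expected step is a 3.3-fold higher number from compound 3 to compound 4 (0.52 log units; beyond the scatter), and the estimate is 3500 nM (range 800 nM to 15000 nM).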

Compound 4, half-maximal effective concentration: 3280 nM
Beside the measured number, compound 4's estimate is 1.1-fold (0.03 log units) above it; low and high end bracket the measured number.
By their numbers in this assay, from the lowest: compound 2; then compounds 3 and 1 (each within the scatter of the next); then compound 4.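

Removing the chain raises the number in this assay whichever end group it carried: a 3.1-fold higher number from compound 3 to compound 4 (0.49 log units; beyond the scatter), a 2.8-fold higher number from compound 1 to compound 4 (0.44 log units; beyond the scatter), and a 26-fold higher number from compound 2 to compound 4 (1.42 log units; beyond the scatter). All three steps lie beyond the scatter, so each chain gives a lower number than hydrogen at this place, and the largest step is the one that removes 2-(dimethylamino)ethyl. No measurement at hand accounts for these differences.

Still open, from the compounds shown here alone, is how a primary amine, a carboxylic acid or a longer chain ending in dimethylamino would compare with compound 2 at this place.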